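Removing tert-butoxycarbonyl from compound 2

A few compounds are considered here, and "the series" means these few. Any claim that something is new, unique, unknown or untested is made for them only; others in the source may bear on it.

Measured so far in a physicochemical assay for solubility (a higher number here means a more soluble compound, a lower number a less soluble compound), for two compounds
Compound 1 `CN(C)c1ccc(C(=O)N2CCC(NS(=O)(=O)c3cc(S(=O)(=O)c4ccccc4)ccc3C(F)(F)F)CC2)cn1` with 12500 nM
Compound 2 `CC(C)(C)OC(=O)N1CCC(CC(=O)N2CCC(NS(=O)(=O)c3cc(S(=O)(=O)c4ccccc4)ccc3C(F)(F)F)CC2)CC1` with 12500 nM

In this assay compound 2 stands at 12500 nM and is level with compound 1 within the usual scatter. Compound 3 `O=C(CC1CCNCC1)N1CCC(NS(=O)(=O)c2cc(S(=O)(=O)c3ccccc3)ccc2C(F)(F)F)CC1` has hydrogen in place of tert-butoxycarbonyl on an amine nitrogen in a ring and awaits its measurement. For the measured compounds named here, no measured pair shows this change directly, so no step beyond the scatter is expected in this assay here. The expected no change at the digits printed from compound 2 to compound 3 (within the scatter) is estimated to stay within that scatter. Compound 3 is estimated at 12500 nM with an expected range from 7000 nM to 25000 nM once measured.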

Compound 3, solubility: 100000 nM
The estimate for compound 3 lay 8.0-fold (0.90 log units) below the measured number, and the stated range ends below it.
By their numbers in this assay, from the lowest: compounds 1 and 2 (each within the scatter of the next); then compound 3.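

In this assay, for the compounds shown here, the amine nitrogen in the ring proves to be a position that can move the number: hydrogen in place of tert-butoxycarbonyl gives an 8.0-fold higher number from compound 2 to compound 3 (0.90 log units; beyond the scatter) and the two earlier compounds, level with each other, showed no such step. Compound 3 also separates from compound 1, with an 8.0-fold higher number from compound 1 to compound 3 (0.90 log units; beyond the scatter) where (piperidin-4-yl)methyl replaces 6-(dimethylamino)pyridin-3-yl on a carbonyl carbon. Nothing available explains this rise.

The compounds shown leave open where a methyl or an acetyl group on that ring nitrogen would stand in this assay and so whether hydrogen itself is needed for the higher number.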